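From Ethylamino to Cyclobutyloxy on the Shared Core

This account rests on a few compounds, and the source may have more. Where it says the series, first, only, none or still open, it means among the compounds named here.

In an assay on membranes from HeLa cells for displacement of a labelled ligand from adenosine receptor A3 (Homo sapiens), read by scintillation counting, with a stated time of 180 min, tested at 1 uM (a higher number here means more inhibition at the concentration tested (going by the name of the read-out), a lower number less inhibition), compound 2 `CCNC(=O)C1=C(C)NC(=O)NC1c1ccsc1` gives 1%, the lowest of the three numbers, though all three lie within the scatter of one another: compound 3 `CC1=C(c2ncc(C)o2)C(c2ccsc2)NC(=O)N1` gives 2% and compound 1 `CCNC(=O)C1=C(C)NC(=O)NC1c1cccs1` gives 4%. The steps of a number 3 percentage points lower from compound 1 to compound 2 (within the scatter) and a number 1 percentage points higher from compound 2 to compound 3 (within the scatter) both stay within the scatter. Compound 4 `CC1=C(C(=O)OC2CCC2)C(c2ccsc2)NC(=O)N1` differs from compound 2 by cyclobutyloxy in place of ethylamino on a carbonyl carbon. Going by the values given here, the only measured step at this part of the core, a number 1 percentage points higher from compound 2 to compound 3 (within the scatter), exchanged the whole ethylcarbamoyl group and moved nothing beyond the scatter, and every measured compound sits near the bottom of the scale, so no step beyond the scatter is expected in this assay. Compound 4 is expected to give 3%, between -5% and 12%. The expected step is a number 2 percentage points higher from compound 2 to compound 4 (within the scatter), within the scatter.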

Compound 4, a percentage reported as inhibition, at one concentration (the size of the read-out at that concentration, not a potency): 3%
The estimate for compound 4 equals the measured number at the digits printed; the measured number falls inside the stated range.
By their numbers in this assay, from the lowest: compounds 2, 3, 4 and 1 (each within the scatter of the next).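

The step of a number 2 percentage points higher from compound 2 to compound 4 (within the scatter) in this assay shows that cyclobutyloxy in place of ethylamino on a carbonyl carbon, a change that keeps the carbonyl, moves nothing beyond the scatter. The loss of the ethylamino hydrogen-bond donor and the entry of a four-membered carbon ring thus leave the number near the bottom of the scale. Nothing available gives a reason for this outcome. Still open, on these data alone, is whether a carboxylic acid, a primary amide or a longer chain such as hexyloxy on this carbonyl carbon would lift the number beyond the scatter.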